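Sulfanyl in Place of Chloro on Two Related Cores

The source may hold more compounds than are shown below. What is called first, only, known or untested is meant among the compounds shown, and "the series" means these compounds.

compound 1 `CC(=O)OC(C)n1cnc2c(Cl)nc(N)nc21`: > 500000 nM
compound 2 `CC(=O)OCCOn1cnc2c(Cl)nc(N)nc21`: > 500000 nM
compound 3 `CC(=O)OC(C)n1cnc2c(S)nc(N)nc21`: 160 nM

In a functional assay on SW-620 cells (Homo sapiens) for inhibition (on this read-out lower numbers stand for stronger inhibition and higher numbers for weaker inhibition), compound 1 gives > 500000 nM, which is a limit of the assay rather than a number. Compound 2 gives > 500000 nM in this assay, again a limit. Compound 3 gives 160 nM in this assay. Compound 3 arises from compound 1 by sulfanyl in place of chloro on an aromatic carbon, and this step is an at least 3100-fold lower number from compound 1 to compound 3 (3.49 log units; beyond the scatter); its size rests on (the limit of > 500000 nM in this assay, at which 2 of the 3 values shown sit). Compound 4 `CC(=O)OCCOn1cnc2c(S)nc(N)nc21` has not yet been measured; it arises from compound 2 by the same change, (sulfanyl in place of chloro on an aromatic carbon). How the core of compound 2 differs from the core of compound 1 is not broken down here. For compound 4 a step of an at least 1200-fold lower number from compound 2 to compound 4 (3.09 log units; beyond the scatter) in this assay is expected, resting on an at least 3100-fold lower number from compound 1 to compound 3 (3.49 log units; beyond the scatter). Compound 4 is estimated at 400 nM, with a likely span from 60 nM to 6000 nM.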

Compound 4, half-maximal inhibitory concentration: 4200 nM
Beside the measured number, compound 4's estimate is 11-fold (1.02 log units) below it; the range from low to high includes it.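

In this assay, sulfanyl in place of chloro on an aromatic carbon again gives a large step on the second core, an at least 110-fold lower number from compound 2 to compound 4 (2.07 log units; beyond the scatter). The direction of the change therefore carries over from the core of compound 1 to the core of compound 2, and the two steps can be set side by side: the same change on two cores in this assay, an at least 3100-fold lower number (3.49 log units; beyond the scatter) from compound 1 to compound 3 and an at least 110-fold lower number (2.07 log units; beyond the scatter) from compound 2 to compound 4; the limit leaves it open whether they differ Neither step has a true size, since each starts from a limit rather than a number, so this does not show that the change is worth the same on both cores: the limit of > 500000 nM in this assay, at which 2 of the 4 values shown sit.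

The compounds shown leave open whether an amine or a methylsulfanyl group on that aromatic carbon would act like sulfanyl. They also leave open whether the step holds on a core carrying a longer chain.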